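A Chloro for a Hydrogen on the Shared Core

This account rests on a few compounds, and the source may have more. Where it says the series, first, only, none or still open, it means among the compounds named here.

Compound 1: `ClCc1cccc(Cn2cnc3ncnc(Cl)c32)c1`, 1770 nM
Compound 2: `ClCc1cccc(Cn2cnc3c(Cl)nc(Cl)nc32)c1`, 1580 nM

In a functional assay on OVCAR-3 cells (Homo sapiens) for cytotoxicity, read by sulforhodamine B assay, with a stated time of 48 h (a higher number here means a weaker inhibitor of growth, a lower number a stronger inhibitor of growth), compound 1 gives 1770 nM, the highest of the two numbers, while compound 2 gives 1580 nM, a number within the scatter of that of compound 1. Compound 3, `ClCc1cccc(Cn2cnc3nc(Cl)nc(Cl)c32)c1`, is not yet measured. It differs from compound 1 by chloro in place of hydrogen on an aromatic carbon. Among the compounds with values here, no step between measured compounds is known here. Since compound 1 sits within the scatter of compound 2, which gives 1580 nM, no step beyond the scatter is expected in this assay, and the estimated step of a 1.1-fold lower number from compound 1 to compound 3 (0.04 log units; within the scatter) reflects this. Compound 3 is expected to give 1600 nM, with a range from 600 nM to 4500 nM.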

Compound 3, concentration for 50% growth inhibition: 1510 nM
Compound 3: the middle estimate sits 1.1-fold (0.03 log units) above what was measured, within the range that was stated.
By their numbers in this assay, from the lowest: compounds 3, 2 and 1 (each within the scatter of the next).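

On the aromatic carbon between two ring nitrogen atoms, chloro in place of hydrogen gives in this assay a 1.2-fold lower number from compound 1 to compound 3 (0.07 log units; within the scatter), so the two compounds cannot be told apart at this position. Within the data shown here, this is the first step between measured compounds that differ in one place, and it shows that this carbon can carry a chloro group while the number stays within the scatter. No measured evidence bears on this result. As far as these compounds go, whether an amine, a methoxy group or a longer chain on this carbon would also stay within the scatter remains open.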